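Shortening the amide chain in a cytotoxicity series

A few compounds are considered here, and "the series" means these few. Any claim that something is new, unique, unknown or untested is made for them only; others in the source may bear on it.

Of the compounds shown here, three built on one shared core have been tested in a functional assay on HeLa cells (Homo sapiens) for cytotoxicity, read by MTT assay, with a stated time of 24 h; on this read-out higher numbers stand for weaker inhibition and lower numbers for stronger inhibition. Compound 1, `C=CC1=C(C(=O)NCc2ccc(C)cc2)C(c2ccc(F)cc2)OC1`, is one of them; in this assay compound 1 gives > 100000 nM, which is a limit of the assay and not a measured number. Compound 2, `C=CC1=C(C(=O)NCCCCC)C(c2ccc(Cl)c(Cl)c2)OC1`, carries a pentylamino amide on the same core; in this assay compound 2 gives > 100000 nM, again a limit rather than a number. Compound 3, `C=CC1=C(C(=O)NC(C)(C)C)C(c2ccc(OC)cc2)OC1`, with a different amide substituent, gives > 100000 nM, also a limit. Within the data shown here, compound 2 therefore stands exactly where every value so far stands: at the limit of > 100000 nM in this assay, at which 3 of the 3 values shown sit, with no compound separating itself from the others.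

Compound 4, `C=CC1=C(C(=O)NCC(C)C)C(c2ccc(Cl)c(Cl)c2)OC1`, differs from compound 2 in a single place: isopropyl in place of butyl on a saturated chain carbon bound to an amide-type nitrogen. Among the measured compounds shown here, every measured compound, whatever its amide substituent, sits at the same limit, and no step between measured compounds is available to size this kind of change. No shift beyond the usual scatter is expected, and the expected step is a step that the limit leaves unreadable from compound 2 to compound 4, essentially none. Compound 4 is expected to give about 150000 nM, with a range from 60000 nM to 400000 nM, and most likely to be reported once more only as a limit.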

Compound 4, half-maximal inhibitory concentration: 60100 nM
Estimate against measurement, compound 4: 2.5-fold (0.40 log units) above; the range from low to high includes it.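

In this assay, among these compounds, compound 4 gives 60100 nM, the only actual number in this set, so a value can now be read for a compound with this kind of amide chain. Putting isopropyl in place of butyl on a saturated chain carbon bound to an amide-type nitrogen, which can also be read as pentylamino to isobutylamino, gives an at least 1.6-fold lower number from compound 2 to compound 4 (0.22 log units; that floor lies within the scatter); the true step may be larger, but the part that can be read does not go beyond the usual scatter. The step therefore has only a floor, and the other compounds give no scale for its full size: the limit of > 100000 nM in this assay, at which 3 of the 4 values shown sit.

A straight butylamino amide on the same core would help to separate the effect of the shorter chain from that of the branch. A carboxylic acid or an amine at the end of the chain would show whether this position can take a group of a very different kind.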